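A few compounds are considered here, and "the series" means these few. Any claim that something is new, unique, unknown or untested is made for them only; others in the source may bear on it.

Within the data shown here, compound 3 `c1cn2cc(-c3ccsc3)nc(-c3ccc4ncn(C5CCCCC5)c4c3)c2n1` stands second highest of the three compounds measured so far in a functional assay on NCI-H522 cells (Homo sapiens) for inhibition, read by sulforhodamine B assay, with a stated time of 48 h, tested at 10 uM (on this read-out higher numbers stand for more inhibition at the one concentration tested (going by the name of the read-out) and lower numbers for less inhibition), where compound 3 gives 10.3%. Its nearest neighbour is compound 2 `COc1ccc(-c2cn3ccnc3c(-c3ccc4ncn(C5CCCCC5)c4c3)n2)cc1`, which in this assay gives -20.9%, the gap being a number 31.2 percentage points higher from compound 2 to compound 3 (beyond the scatter). Furthest away is compound 1 `c1ccc(-c2cn3ccnc3c(-c3ccc4ncn(C5CCCCC5)c4c3)n2)cc1`, which gives 58.1%, and the step from it is a number 47.8 percentage points lower from compound 1 to compound 3 (beyond the scatter).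

The change to compound 4 `CC(=O)c1ccc(-c2cn3ccnc3c(-c3ccc4ncn(C5CCCCC5)c4c3)n2)cc1` is 4-acetylphenyl in place of thiophen-3-yl on an aromatic carbon. Among the measured compounds shown here, two measured steps bear on it. The step of a number 47.8 percentage points lower from compound 1 to compound 3 (beyond the scatter) shows that leaving a phenyl for a thiophen-3-yl cost a large amount, so returning to a six-membered carbon ring might recover some inhibition. Against that, the step of a number 79 percentage points lower from compound 1 to compound 2 (beyond the scatter) shows that a methoxy added to the phenyl of compound 1 cost even more, and compound 4 likewise carries a group, an acetyl, on its phenyl; no measured compound tells how an acetyl behaves. Weighing these, compound 4 is expected to rise modestly, by a number 14.7 percentage points higher from compound 3 to compound 4 (beyond the scatter), to an estimated 25%, within a wide range from -20% to 65%.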

Compound 4, a percentage reported as inhibition, at one concentration (the size of the read-out at that concentration, not a potency): 10.4%
The estimate for compound 4 lay 14.6 percentage points above the measured number; measured number inside the range.
By their numbers in this assay, from the lowest: compound 2; then compounds 3 and 4 (each within the scatter of the next); then compound 1.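

In this assay, at this position on the aromatic carbon, a 4-acetylphenyl and a thiophen-3-yl are not told apart, the swap giving a number 0.1 percentage points higher from compound 3 to compound 4 (within the scatter). The loss on placing a group on the phenyl of compound 1 is not confined to methoxy, since acetyl in place of hydrogen gives a number 47.7 percentage points lower from compound 1 to compound 4 (beyond the scatter), so compound 2 and compound 4 both lie well under compound 1. The two groups are still not equal, as acetyl in place of methoxy gives a number 31.3 percentage points higher from compound 2 to compound 4 (beyond the scatter).

Nothing available explains these steps. Going by these compounds, it remains open whether a fluorine, a methyl, an amine or a carboxylic acid on the phenyl would keep the level of compound 1 or lose it as well.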